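Removing the chloro group from compound 1

The compounds below may be only part of what the source reports. "The series", "measured", "known", "first", "only" and "open" are said of these compounds alone.

Compound 1 `O=C(O)CCc1ccc(NCc2ccc(Cl)cc2)cc1` stands lowest of the two numbers in hand. In a functional assay for agonist activity at Free fatty acid receptor 1 (Homo sapiens) (a lower number here means that less compound is needed, a higher number that more compound is needed for the effect), compound 1 gives 1000 nM. Compound 2 `CC(C(=O)O)c1ccc(NCc2cccc(Oc3ccccc3)c2)cc1`, which differs from it in more than one place, gives in this assay 16600 nM, a gap that lies beyond the usual scatter, so compound 1 is the more potent of the two measured compounds; no single-point comparison connects them.

Compound 3 `O=C(O)CCc1ccc(NCc2ccccc2)cc1` differs from compound 1 in one place only: hydrogen in place of chloro on an aromatic carbon. Going by the values given here, no measured pair in this set shows this exact change, so its size must be judged without a precedent. The writer expects the number for compound 3 to rise modestly, by a step of a 2.5-fold higher number from compound 1 to compound 3 (0.40 log units; beyond the scatter), probably somewhat beyond the scatter but not by much. Compound 3 is therefore estimated at 2500 nM in this assay, within a range from 1000 nM to 6300 nM.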

Compound 3, half-maximal effective concentration: 7940 nM
For compound 3 the middle estimate is 3.2-fold (0.50 log units) below the measured one; measured number above the stated range.
By their numbers in this assay, from the lowest: compound 1; then compound 3; then compound 2.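

Going by these compounds alone, the pair gives the first direct reading of this position: in this assay, replacing the chloro group on the aromatic carbon para to a large group with hydrogen brings a 7.9-fold higher number from compound 1 to compound 3 (0.90 log units; beyond the scatter). A single heavy atom at this place therefore accounts for a clear share of the potency of compound 1, which the comparison with compound 2, differing in more than one place, could not isolate. Nothing measured here bears on why this one atom counts for so much.

Going by these compounds, it remains open whether the chloro group is specifically required or whether a fluoro, bromo, methyl or methoxy group at this place would serve as well or better. On these data alone, how a chloro group would fare at another carbon of the same ring also stays open.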